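Iodo for methyl on a butenyl chain: expected binding

This account rests on a few compounds, and the source may have more. Where it says the series, first, only, none or still open, it means among the compounds named here.

Compound 1 `OC1CCNCC1N1CCN(c2ccccc2)CC1`: in an assay on PC-12 cells for displacement of a labelled ligand from vesicular acetylcholine transporter (Homo sapiens) (on this read-out lower numbers stand for stronger inhibition and higher numbers for weaker inhibition), compound 1 gives > 100 nM, which is a limit of the assay.
Compound 2 `C=CCN1CCC(O)C(N2CCN(c3ccccc3)CC2)C1`: compound 2 gives > 100 nM, also a limit.
Compound 3 `C/C=C/CN1CCC(O)C(N2CCN(c3ccccc3)CC2)C1`: compound 3 gives > 100 nM, again a limit.

Compound 3 thus stands at the limit, where every measured value sits (the limit of > 100 nM in this assay, at which 3 of the 3 values shown sit). Among the compounds with values here, the steps a step that the two limits leave unreadable from compound 1 to compound 2, a step that the two limits leave unreadable from compound 1 to compound 3 and a step that the two limits leave unreadable from compound 2 to compound 3 are consequently of unreadable size, and no measured step shows how a change on the double-bonded chain affects binding. Compound 4 `OC1CCN(C/C=C/I)CC1N1CCN(c2ccccc2)CC1` differs from compound 3 by iodo in place of methyl on a double-bonded chain carbon bound to a double-bonded chain carbon. With only limits to draw on, the step that the limit leaves unreadable from compound 3 to compound 4 is expected to be small or unreadable, and compound 4 will most likely again return only a limit. Compound 4 is estimated at 300 nM, with a range from 80 nM to 3000 nM.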

Compound 4, half-maximal inhibitory concentration: > 100 nM
Compound 4: only a limit was reported; the forecaster's own chance of this, stated with the estimate: 75%; the middle value does not contradict the limit.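

Within the data shown here, compound 4 gives > 100 nM, which is a limit of the assay, so no step from compound 1, compound 2 or compound 3 to compound 4 can be read. How strongly each compound binds, and whether changing the chain alters binding, stays open: the limit of > 100 nM in this assay, at which 4 of the 4 values shown sit.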